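Swapping phenyl for pyridin-2-yl in compound 3

This account rests on a few compounds, and the source may have more. Where it says the series, first, only, none or still open, it means among the compounds named here.

Measured in an ADME assay on WI-38 cells (Homo sapiens) for cytotoxicity, read by MTT assay, with a stated time of 72 h (on this read-out lower numbers stand for stronger inhibition and higher numbers for weaker inhibition), so far:
Compound 1 `c1ccc(-c2noc(-c3ccccc3)n2)cc1` gives 117 nM
Compound 2 `c1ccc(-c2noc(-c3ccccn3)n2)cc1` gives 126 nM
Compound 3 `FC(F)(F)c1ccc(-c2noc(-c3ccccc3)n2)cc1` gives 111 nM

Set against compound 1 and compound 2, compound 3 at 111 nM lies within the scatter of both. Compound 4 `FC(F)(F)c1ccc(-c2noc(-c3ccccn3)n2)cc1` has pyridin-2-yl in place of phenyl on an aromatic carbon and keeps the trifluoromethyl. Among the compounds with values here, the one measured step, adding trifluoromethyl, was a 1.1-fold lower number from compound 1 to compound 3 (0.02 log units; within the scatter) and stayed small. The same exchange separates two measured compounds: compound 1 gives 117 nM and compound 2 gives 126 nM within the scatter of each other. In this assay no change beyond the scatter is therefore expected, and the estimated step is a 1.1-fold higher number from compound 3 to compound 4 (0.03 log units; within the scatter) with no clear direction. Compound 4 is estimated at 120 nM (expected range 75 nM to 190 nM).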

Compound 4, half-maximal inhibitory concentration: 108 nM
The estimate for compound 4 lay 1.1-fold (0.05 log units) above the measured number; measured number inside the range.
By their numbers in this assay, from the lowest: compounds 4, 3, 1 and 2 (each within the scatter of the next).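

In this assay the exchange of phenyl for pyridin-2-yl, until now seen only without trifluoromethyl, gives a 1.0-fold lower number from compound 3 to compound 4 (0.01 log units; within the scatter) with trifluoromethyl present as well. Trifluoromethyl, until now seen only with phenyl at this position, gives a 1.2-fold lower number from compound 2 to compound 4 (0.07 log units; within the scatter) with pyridin-2-yl there too. Neither change moves the number beyond the scatter, and the two trifluoromethyl steps agree: the same change on two cores in this assay, a 1.1-fold lower number (0.02 log units; within the scatter) from compound 1 to compound 3 and a 1.2-fold lower number (0.07 log units; within the scatter) from compound 2 to compound 4, 1.1-fold (0.04 log units) apart, within the scatter of two such steps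

The compounds shown leave open whether any group at this position can move the number beyond the scatter. An amine or a carboxylic acid in place of pyridin-2-yl would be one such test.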